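Fluoro for Hydrogen on the Core of Compound 1

The source may hold more compounds than are shown below. What is called first, only, known or untested is meant among the compounds shown, and "the series" means these compounds.

Compound 1 `COC(CN(c1ccccc1CO)S(=O)(=O)c1ccc([N+](=O)[O-])cc1)n1ccc(=O)[nH]c1=O` was tested in a functional assay on MCF7 cells (Homo sapiens) for antiproliferative activity (a higher number here means a weaker inhibitor, a lower number a stronger inhibitor), and gave 45800 nM. Among the three measured compounds this is the highest number. Compound 2 `O=[N+]([O-])c1ccccc1S(=O)(=O)N1CC(n2cnc3ncnc(Sc4ccccc4)c32)OCc2ccccc21` gives 2590 nM in this assay, and compound 3 `FC(F)(F)c1ncnc2c1ncn2C1COc2ccccc2CO1` gives 1250 nM. Both of these differences from compound 1 lie beyond the usual scatter, so compound 1 is the weakest inhibitor of the three. Going by the values given here, neither compound 2 nor compound 3 shares the change considered here, so no measured pair bears directly on it.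

Compound 4 `COC(CN(c1ccccc1CO)S(=O)(=O)c1ccc([N+](=O)[O-])cc1)n1cc(F)c(=O)[nH]c1=O` differs from compound 1 by fluoro in place of hydrogen on an aromatic carbon. Among the compounds with values here, no measured step of this kind is available. The change enters a single heavy atom while the rest of the structure is kept. The expectation is a small step, leaning toward a lower number but possibly within the scatter. The expected step is a 1.5-fold lower number from compound 1 to compound 4 (0.18 log units; within the scatter). Compound 4 is therefore estimated at 30000 nM, with a range from 10000 nM to 90000 nM.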

Compound 4, half-maximal inhibitory concentration: 55200 nM
Estimate against measurement, compound 4: 1.8-fold (0.26 log units) below; the range from low to high includes it.
By their numbers in this assay, from the lowest: compound 3; then compound 2; then compounds 1 and 4 (each within the scatter of the next).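

In this assay, going by these compounds alone, the swap of fluoro for hydrogen on an aromatic carbon of the six-membered aromatic ring with 2 nitrogen gives a 1.2-fold higher number from compound 1 to compound 4 (0.08 log units; within the scatter), the first measured step at this position. It shows that this single added fluorine atom, with the rest of the structure kept, leaves compound 1 and compound 4 within the scatter of each other, so the two cannot be told apart in this read-out. No measured information on either compound accounts for this result.

Going by these compounds, whether a chloro, a methyl or an amine at this same position would also stay within the scatter of compound 1 remains open. So does whether fluoro on this ring would give a similar step if the sulfonamide side of the structure were changed.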